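This account rests on a few compounds, and the source may have more. Where it says the series, first, only, none or still open, it means among the compounds named here.

Measured so far:
compound 1 `O=c1cc(-c2cccc(O)c2)oc2cccc(O)c12`: 32000 nM
compound 2 `O=c1cc(-c2ccc(O)cc2)oc2cccc(O)c12`: 67800 nM
compound 3 `O=c1cc(-c2ccc(O)c(O)c2)oc2cccc(O)c12`: 4900 nM

In a functional assay on cells (Neutrophil, Homo sapiens) for inhibition, read by chemiluminescence, with a stated time of 5 min (on this read-out higher numbers stand for weaker inhibition and lower numbers for stronger inhibition), compound 1 gives 32000 nM, the second highest of the three numbers, with compound 2 above it and compound 3 below it.

Compound 4 `O=c1cc(-c2cccc(O)c2)oc2cc(O)cc(O)c12` differs from compound 1 as follows: hydroxy in place of hydrogen on an aromatic carbon. This is hydroxy in place of hydrogen on an aromatic carbon, on the part of the core that is a fused system of two rings.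

Two measured steps are the same kind of exchange. The modest one is a 6.5-fold lower number from compound 1 to compound 3 (0.81 log units; beyond the scatter), and the large one is a 14-fold lower number from compound 2 to compound 3 (1.14 log units; beyond the scatter). Both lead to a lower number, but neither places its hydroxy on the ring changed here, so they suggest a direction and say little about size. Going by the values given here, no measured step covers this place.

A lower number is expected in this assay, on the scale of the modest step or smaller, and the range allows for no real change. The expected step is a 2.1-fold lower number from compound 1 to compound 4 (0.33 log units; beyond the scatter). For compound 4 the estimated value is 15000 nM, with an expected range from 5000 nM to 45000 nM.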

Compound 4, half-maximal inhibitory concentration: 15800 nM
Compound 4: the middle estimate sits 1.1-fold (0.02 log units) below what was measured; the measured number falls inside the stated range.
By their numbers in this assay, from the lowest: compound 3; then compound 4; then compound 1; then compound 2.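

Hydroxy in place of hydrogen on the fused system of two rings now has a measured step of its own in this assay: a 2.0-fold lower number from compound 1 to compound 4 (0.31 log units; beyond the scatter). This shows that the position, meta to a hydroxy group and para to a fused ring, responds to the change, though less than the largest step seen on the other ring. The same exchange does not carry one size across the series: the same change on two cores in this assay, a 14-fold lower number (1.14 log units; beyond the scatter) from compound 2 to compound 3 and a 2.0-fold lower number (0.31 log units; beyond the scatter) from compound 1 to compound 4, 6.8-fold (0.83 log units) apart, beyond the scatter of two such steps

The compounds shown leave open whether the lower number belongs to hydroxy itself, which a methoxy group or an amine at this place would test. Going by these compounds alone, also open is whether this step would add to the one leading to compound 3 if both new hydroxy groups stood on a single core.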